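A few compounds are considered here, and "the series" means these few. Any claim that something is new, unique, unknown or untested is made for them only; others in the source may bear on it.

Measured in a functional assay on I10 cells (Mus musculus) for inhibition, read by MTT assay, with a stated time of 72 h; on this read-out lower numbers stand for stronger inhibition and higher numbers for weaker inhibition:
- Compound 1 `C=CCc1ccc(OCc2c(Cl)cccc2Cl)c(-c2ccc(OCc3c(Cl)cccc3Cl)c(CC=C)c2)c1`: > 50000 nM
- Compound 2 `C=CCc1ccc(OCc2ccc(Cl)c(Cl)c2)c(-c2ccc(O)c(CC=C)c2)c1`: 12200 nM

The entry for compound 1 is a limit of the assay. Among the compounds with values here, compound 2 at 12200 nM is the only actual number so far. Compound 3 `C=CCc1ccc(OCc2c(Cl)cccc2Cl)c(-c2ccc(O)c(CC=C)c2)c1` is still to be measured in this assay. It differs from compound 2 in one place: 2,6-dichlorophenyl in place of 3,4-dichlorophenyl on a saturated chain carbon bound to an oxygen on an aromatic ring. Within the data shown here, no measured step covers this exchange, so the expectation is no change beyond the scatter, an estimated 1.0-fold lower number from compound 2 to compound 3 (0.01 log units; within the scatter). For compound 3 the expected value is 12000 nM, with an estimated range of 5000 nM to 30000 nM.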

Compound 3, half-maximal inhibitory concentration: 17200 nM
For compound 3 the middle estimate is 1.4-fold (0.16 log units) below the measured one, within the range that was stated.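

In this assay, 2,6-dichlorophenyl in place of 3,4-dichlorophenyl on a saturated chain carbon bound to an oxygen on an aromatic ring gives a 1.4-fold higher number from compound 2 to compound 3 (0.15 log units; within the scatter), so the read-out does not separate these two chlorine patterns at this position. Hydrogen in place of 2,6-dichlorobenzyl on an oxygen on an aromatic ring gives an at least 2.9-fold lower number from compound 1 to compound 3 (0.46 log units; beyond the scatter). That step is only a bound, with compound 1 at a limit of the assay: the limit of > 50000 nM in this assay, at which 1 of the 3 values shown sits.

Open, on these data alone, is whether a benzyl group carrying an amine or a carboxylic acid in place of the chlorines would move the number beyond the scatter around compound 2 and compound 3.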